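Aryl exchange on a shared core: estimating compound 3

This account rests on a few compounds, and the source may have more. Where it says the series, first, only, none or still open, it means among the compounds named here.

Compound 1, `Cn1c(=O)c(=O)n(C2CCCC2)c2nc(N/N=C/c3ccc(C(F)(F)F)cc3)ncc21`, in a functional assay on PC-3 cells (Homo sapiens) for antiproliferative activity, read by MTT assay (a higher number here means a weaker inhibitor, a lower number a stronger inhibitor), gives 23600 nM.
Compound 2, `Cn1c(=O)c(=O)n(C2CCCC2)c2nc(N/N=C/c3ccc(O)c(Br)c3)ncc21`, in this assay gives 11600 nM.

Compound 2 stands lowest of the two numbers, with compound 1 the nearest at a modestly higher value. Compound 3, `Cn1c(=O)c(=O)n(C2CCCC2)c2nc(N/N=C/c3ccc(F)cc3F)ncc21`, differs from compound 2 by 2,4-difluorophenyl in place of 3-bromo-4-hydroxyphenyl on a carbon with a double bond to nitrogen. For the measured compounds named here, the one measured step, a 2.0-fold lower number from compound 1 to compound 2 (0.31 log units; beyond the scatter), is likewise an exchange of the ring on that carbon and was only modest. Going by the values given here, no measured pair tests this particular exchange, so the number for compound 3 is expected to stay close to that of its neighbour. The expected step is a 1.5-fold higher number from compound 2 to compound 3 (0.17 log units; within the scatter), a slight weakening at most. Compound 3 in this assay is estimated at 17000 nM, within a range from 7000 nM to 40000 nM.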

Compound 3, half-maximal inhibitory concentration: 13200 nM
The estimate for compound 3 lay 1.3-fold (0.11 log units) above the measured number; measured number inside the range.
By their numbers in this assay, from the lowest: compounds 2, 3 and 1 (each within the scatter of the next, the first and the last beyond it).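

In this assay the change to 2,4-difluorophenyl gives a 1.1-fold higher number from compound 2 to compound 3 (0.06 log units; within the scatter), so at this carbon with a double bond to nitrogen, the loss of the hydroxyl and bromine of 3-bromo-4-hydroxyphenyl leaves the number within the scatter. The other exchange gives a 1.8-fold lower number from compound 1 to compound 3 (0.25 log units; within the scatter), so compound 3 lies within the scatter of both earlier compounds, although those two differ beyond it. Nothing available explains these results.

The compounds shown leave open whether a dimethylamino group or a carboxylic acid on this phenyl ring would shift the number beyond the scatter.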